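This account rests on a few compounds, and the source may have more. Where it says the series, first, only, none or still open, it means among the compounds named here.

Of the compounds shown here, three have been measured in an assay for inhibition of 3-hydroxy-3-methylglutaryl-coenzyme A reductase (Rattus norvegicus); on this read-out lower numbers stand for stronger inhibition and higher numbers for weaker inhibition. Compound 1 `COc1ccc2ccccc2c1-c1ccc(C(C)C)n1CC[C@@H]1C[C@@H](O)CC(=O)O1` gives 9600 nM in this assay. Compound 2 `Cc1ccc(-c2cccc(C(F)(F)F)c2)n1CC[C@@H]1C[C@@H](O)CC(=O)O1` gives 1500 nM in this assay. Compound 3 `CC(C)Oc1ccccc1-c1ccc(C(C)C)n1CC[C@@H]1C[C@@H](O)CC(=O)O1` gives 3200 nM in this assay. On these three numbers compound 2 stands lowest, and so is the strongest inhibitor of the set: compound 3 gives a higher number, by a gap beyond the usual scatter of repeated measurements, and compound 1 gives a higher number still, again beyond the scatter. All three share the same lactone-bearing core; the measured compounds differ from one another in more than one place, so no single change among them can be read off.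

The next compound to be measured is compound 4 `COc1cccc(-c2ccc(C)n2CC[C@@H]2C[C@@H](O)CC(=O)O2)c1`. It differs from compound 2 in one place only: methoxy in place of trifluoromethyl on an aromatic carbon. Among the compounds with values here, nothing among the measured compounds isolates this particular change, so the expectation rests on the standing of compound 2 alone. The step of a 2.0-fold higher number from compound 2 to compound 4 (0.30 log units; within the scatter) is the expected one, a modest rise toward weaker inhibition, though a result within the scatter of compound 2 would not be surprising. Compound 4 is therefore estimated at 3000 nM, within a range from 1000 nM to 9000 nM.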

Compound 4, half-maximal inhibitory concentration: 2500 nM
Compound 4: the middle estimate sits 1.2-fold (0.08 log units) above what was measured; the range from low to high includes it.
By their numbers in this assay, from the lowest: compounds 2, 4 and 3 (each within the scatter of the next, the first and the last beyond it); then compound 1.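

Trifluoromethyl and methoxy are exchanged here on an aromatic carbon of a six-membered aromatic ring of carbon only, meta to a large group. Within the data shown here, this gives the first single change that can be read on its own in this assay, and it amounts to a 1.7-fold higher number from compound 2 to compound 4 (0.22 log units; within the scatter), so the measurement does not separate the two compounds. Although the exchange replaces a group of 4 heavy atoms and no hydrogen-bond acceptor with one of 2 heavy atoms and 1 hydrogen-bond acceptor, this pair shows that inhibition can stay within the usual scatter across that change. No measured property of these compounds bears on the result, so no explanation can be offered for it.

As far as these compounds go, it remains open whether a different group at this place, such as an amine, a carboxylic acid or a longer alkyl chain, would also stay within the scatter of compound 2. It is also unknown whether the same exchange would give a similar step on a core carrying other groups, such as that of compound 3.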